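A few compounds are considered here, and "the series" means these few. Any claim that something is new, unique, unknown or untested is made for them only; others in the source may bear on it.

Series notes, a functional assay on HeLa cells (Homo sapiens) for antiproliferative activity, read by MTT assay, with a stated time of 48 h; a lower number here means a stronger inhibitor of growth, a higher number a weaker inhibitor of growth:

- compound 1 `COc1cc2c(cc1O)C(=O)/C(=C/c1cc(OC)c(OC)c(OC)c1)C2` gives > 10000 nM in this assay, a limit.
- compound 2 `COc1cc2c(cc1O)C(=O)/C(=C/c1ccc(OC)c(OC)c1OC)C2` gives 1590 nM in this assay.
- compound 3 `COc1cc2c(cc1OC)C(=O)/C(=C/c1cc(OC)c(OC)c(OC)c1)C2` gives > 10000 nM in this assay, a limit.

Compound 2 carries the only number shown; the other two values are limits. Compounds 1 and 2 have the same atoms joined differently; the difference between their cores is not broken down here.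

The change from compound 1 to compound 3 is methyl in place of hydrogen on an oxygen on an aromatic ring. The step that the two limits leave unreadable from compound 1 to compound 3 cannot be read because the limit of > 10000 nM in this assay, at which 2 of the 3 values shown sit: both ends sit at that limit, so the size of the step is not known.

The same change is now made from compound 2 to compound 4 `COc1cc2c(cc1OC)C(=O)/C(=C/c1ccc(OC)c(OC)c1OC)C2`: methyl in place of hydrogen on an oxygen on an aromatic ring, at a place described in the same words as for compounds 1 and 3. The measured pair gives no reading of its size, so the expectation for compound 4 rests on compound 2 at 1590 nM and on where compound 3 stands. Compound 3, which carries the same methyl group, sits at a limit of this assay, and compound 4 may do the same. Compound 4 is expected to be weaker than compound 2, by an estimated step of a 3.1-fold higher number from compound 2 to compound 4 (0.50 log units; beyond the scatter). The estimate for compound 4 in this assay is 5000 nM, within 1500 nM to 20000 nM.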

Compound 4, concentration for 50% growth inhibition: > 10000 nM
Compound 4: a limit, no number; the forecaster's own chance of this, stated with the estimate: 35%; middle value at least 2.0-fold (0.30 log units) away from the limit.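

In this assay, the change from hydroxy to methoxy reads as an at least 6.2-fold higher number from compound 2 to compound 4 (0.79 log units; beyond the scatter); this size is only a floor, as the upper end of the step is a limit and not a number. On these data alone, on this core, then, the methyl group in place of hydrogen goes with weaker growth inhibition, but the true size of the step remains unknown, and the same change on the core of compound 1 cannot be read. The series therefore shows a direction on one core only and gives no measure of how well the change carries from one core to the other, because both ends of the other pair sit at the limit: the limit of > 10000 nM in this assay, at which 3 of the 4 values shown sit.

The compounds shown leave open how an ethyl group or a longer chain ending in an amine would read on that oxygen of the core of compound 2. Also open, as far as these compounds go, is whether a carboxylic acid at that place would bring the core of compound 1 to a readable value.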